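A few compounds are considered here, and "the series" means these few. Any claim that something is new, unique, unknown or untested is made for them only; others in the source may bear on it.

Measured so far in an assay on CHO cells for displacement of a labelled ligand from adenosine receptor A1 (Homo sapiens), read by scintillation counting, with a stated time of 90 min, tested at 1 uM, in the presence of a further agent that is not named here; a lower number here means less inhibition, a higher number more inhibition at the concentration tested (going by the name of the read-out):
compound 1 `CCCn1c(=O)c2[nH]c(-c3ccc(S(=O)(=O)N4CCN(c5ccc(Cl)cc5)CC4)cc3)nc2n(CC)c1=O` gives 24%
compound 2 `CCCn1c(=O)[nH]c2nc(-c3ccc(S(=O)(=O)N4CCN(c5ccc(Br)cc5)CC4)cc3)[nH]c2c1=O` gives 13%
compound 3 `CCCn1c(=O)[nH]c2nc(-c3ccc(S(=O)(=O)N4CCN(c5ccccc5)C(C)C4)cc3)[nH]c2c1=O` gives 15%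

All three numbers sit in the low range of the read-out. Compound 2 holds the lowest of the three; its gap to compound 3 is within the scatter, so no order between those two can be claimed, while its gap to compound 1 lies beyond the scatter, with compound 1 the higher of that pair.

The next compound, compound 4 `CCCn1c(=O)[nH]c2nc(-c3ccc(S(=O)(=O)N4CCN(c5ccc(C)cc5)CC4)cc3)[nH]c2c1=O`, differs from compound 2 in one place: methyl in place of bromo on an aromatic carbon. Among the compounds with values here, no step between two measured compounds is available for this or any other single change in the set, so there is no measured reference for the size of its effect. Given that compound 2 gives 13% and compound 3 gives 15%, both low, the change is not expected to move the number beyond the scatter in either direction; the expected step is a number 2 percentage points higher from compound 2 to compound 4 (within the scatter).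

For compound 4 the estimate in this assay is 15%, with a range from 4% to 28%.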

Compound 4, a percentage reported as inhibition, at one concentration (the size of the read-out at that concentration, not a potency): 12%
For compound 4 the middle estimate is 3 percentage points above the measured one; measured number inside the range.
By their numbers in this assay, from the lowest: compounds 4, 2, 3 and 1 (each within the scatter of the next, the first and the last beyond it).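

Within this assay the step of a number 1 percentage points lower from compound 2 to compound 4 (within the scatter) is the only measured change at a single place in the series, and it gives the 4-bromophenyl to 4-methylphenyl exchange a measured size. On this aromatic carbon, para to a large group, bromo and methyl cannot be told apart in this read-out, and the number stays in the low range with either group. Nothing measured here bears on the reason for this.

Still open, going by these compounds, is whether any group at this position can move the number beyond the scatter, since the two compared here each bring one heavy atom and no hydrogen-bond donors or acceptors. An amine, a carboxylic acid or a longer chain in the same place would put that question to the test.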